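This account rests on a few compounds, and the source may have more. Where it says the series, first, only, none or still open, it means among the compounds named here.

Compound 1 `CCOCCNS(=O)(=O)c1ccc(Nc2nccc(-c3cnc(C)n3C(C)C)n2)cc1` was examined in an ADME assay for inhibition of Bile salt export pump (Homo sapiens), read by scintillation counting, with a stated time of 5 min; a lower number here means a stronger inhibitor, a higher number a weaker inhibitor. In this assay compound 1 gives < 10000 nM, which is a limit of the assay rather than a number. Compound 2 `CCCc1ncc(-c2ccnc(Nc3ccc(S(=O)(=O)NCCOC)cc3)n2)n1C(C)C` was tested in the same way. In this assay compound 2 gives < 10000 nM, again a limit of the assay and not a number. Where compound 2 stands is thus known only through (the limit of < 10000 nM in this assay, at which 2 of the 2 values shown sit), and the two values shown do not separate it from compound 1. Compound 3 `CCCc1ncc(-c2ccnc(Nc3ccc(S(=O)(=O)NCCOC)cc3)n2)n1CC` has not yet been measured in this assay. It differs from compound 2 by hydrogen in place of methyl on a saturated chain carbon bound to an aromatic nitrogen and a saturated chain carbon, which one bond further out reads as isopropyl to ethyl. Among the compounds with values here, with no step between measured compounds to draw on, the step expected is a step that the limit leaves unreadable from compound 2 to compound 3, nothing beyond the scatter. For compound 3 in this assay a value near 5000 nM is estimated, within a range from 1000 nM to 15000 nM, with a good chance that only a limit is reported once more.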

Compound 3, half-maximal inhibitory concentration: < 10000 nM
Compound 3 ended at the assay's limit; the forecaster's own chance of this, stated with the estimate: 70%; the middle value does not contradict the limit.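

In this assay, within the data shown here, compound 3 gives < 10000 nM, again a limit and not a number, and no step from compound 2 to compound 3 can be read. How strongly compound 1, compound 2 and compound 3 each inhibit, and whether they differ at all, stays open: the limit of < 10000 nM in this assay, at which 3 of the 3 values shown sit.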